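A chloro group on compound 3

The source may report more compounds than this note shows. Statements on the series, on what has been measured and on what is new or still open speak of the compounds shown alone.

In a functional assay on Jurkat cells (Homo sapiens) for cytotoxicity, read by luminescence and CellTiter-Glo, with a stated time of 3 days (on this read-out lower numbers stand for stronger inhibition and higher numbers for weaker inhibition), compound 3 `O=C(Nc1cc(C(F)(F)F)cc(C(F)(F)F)c1)c1ccc(-c2ccccc2)cc1O` gives 1240 nM and stands within the usual scatter of the other two measured compounds. Compound 1 `O=C(Nc1cc(C(F)(F)F)cc(C(F)(F)F)c1)c1cc(Cl)c(F)cc1O` gives 730 nM and compound 2 `O=C(Nc1cc(C(F)(F)F)cc(C(F)(F)F)c1)c1cc(Br)c(-c2ccccc2)cc1O` gives 680 nM in this assay as well. The change to compound 4 `O=C(Nc1cc(C(F)(F)F)cc(C(F)(F)F)c1)c1cc(Cl)c(-c2ccccc2)cc1O` is chloro in place of hydrogen on an aromatic carbon with chloro in place of hydrogen on an aromatic carbon, ortho to a phenyl group. The closest measured step, hydrogen in place of bromo on an aromatic carbon, is a 1.8-fold higher number from compound 2 to compound 3 (0.26 log units; within the scatter) and stays within the scatter. The expected step in this assay is therefore a 1.7-fold lower number from compound 3 to compound 4 (0.22 log units; within the scatter) and points to a slightly lower number, but to none beyond the scatter. For compound 4 the estimate is 750 nM with 370 nM and 1500 nM as the expected ends of its range.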

Compound 4, half-maximal inhibitory concentration: 540 nM
For compound 4 the middle estimate is 1.4-fold (0.14 log units) above the measured one; measured number inside the range.
By their numbers in this assay, from the lowest: compounds 4, 2, 1 and 3 (each within the scatter of the next, the first and the last beyond it).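

In this assay, among these compounds, chloro in place of hydrogen on the aromatic carbon ortho to a phenyl group gives a 2.3-fold lower number from compound 3 to compound 4 (0.36 log units; beyond the scatter) and is the first step here to clear the scatter, though only modestly. Halogen identity at this position shows no clear effect, with a 1.3-fold lower number from compound 2 to compound 4 (0.10 log units; within the scatter) for chloro in place of bromo, and phenyl in place of fluoro gives a 1.4-fold lower number from compound 1 to compound 4 (0.13 log units; within the scatter) in the same way. Nothing measured here explains the gain from chloro.

From the compounds shown here alone, whether a methyl, a methoxy or an amine at this position would match chloro remains open. So does whether chloro has the same effect on other parts of the shared core.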